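Swapping a Chloro for a Methyl on the Benzoyl Ring

The compounds below may be only part of what the source reports. "The series", "measured", "known", "first", "only" and "open" are said of these compounds alone.

Measured so far:
- compound 1 `Cc1ccc(C(=O)c2cc(F)c(OCC(=O)NNC(=O)c3ccc(=O)oc3)c(Cl)c2)cc1` — 29100 nM
- compound 2 `Cn1cnc(C(=O)NNC(=O)COc2c(F)cc(C(=O)c3ccc(F)cc3)cc2Cl)c1` — 44600 nM
- compound 3 `Cn1cnc(C(=O)NNC(=O)COc2c(F)cc(C(=O)c3ccc(Cl)cc3)cc2Cl)c1` — 47300 nM

All three compounds were tested in a functional assay on MCF7 cells (Homo sapiens) for cytotoxicity, read by trypan blue exclusion, with a stated time of 48 h; a higher number here means a weaker inhibitor, a lower number a stronger inhibitor. Among them, compound 3 shows the highest number, but this means little: compound 2 sits a step away that is within the scatter, a 1.1-fold higher number from compound 2 to compound 3 (0.03 log units; within the scatter), and even compound 1, the furthest of the three, lies within the scatter of compound 3. On the numbers shown, the three compounds cannot be told apart.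

Compound 4 `Cc1ccc(C(=O)c2cc(F)c(OCC(=O)NNC(=O)c3cn(C)cn3)c(Cl)c2)cc1` has not yet been measured. It differs from compound 3 by one change, (methyl in place of chloro on an aromatic carbon). For the measured compounds named here, the only measured single-place step, from compound 2 to compound 3, exchanges one halogen for another on that same aromatic carbon and does not move the number beyond the scatter. Going by the values given here, no measured step exchanges a halogen for a methyl at this position, so there is no direct precedent. Compound 1 carries a methyl there but also a different acyl group on the hydrazide, so its value cannot be credited to the methyl alone. The step to compound 4 is therefore expected to stay within the scatter, a 1.2-fold lower number from compound 3 to compound 4 (0.07 log units; within the scatter). Compound 4 is estimated at 40000 nM, with a range from 20000 nM to 80000 nM.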

Compound 4, half-maximal inhibitory concentration: 9500 nM
Compound 4: the middle estimate sits 4.2-fold (0.62 log units) above what was measured, and the stated range ends above it.
By their numbers in this assay, from the lowest: compound 4; then compounds 1, 2 and 3 (each within the scatter of the next).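

In this assay, the two halogens at this position could not be told apart, a 1.1-fold higher number from compound 2 to compound 3 (0.03 log units; within the scatter), but a methyl in the same place clearly separates from both: a 5.0-fold lower number from compound 3 to compound 4 (0.70 log units; beyond the scatter), and a 4.7-fold lower number from compound 2 to compound 4 (0.67 log units; beyond the scatter). With that methyl held fixed, the group on the carbonyl carbon also matters, as a five-membered aromatic ring in place of a six-membered one gives a 3.1-fold lower number from compound 1 to compound 4 (0.49 log units; beyond the scatter). Nothing available explains why the methyl differs from the halogens.

Going by these compounds, it remains open whether the effect is specific to methyl, since an ethyl, a methoxy or a bare hydrogen at this position could show how far the trend extends. The compounds also leave unclear whether a chloro or fluoro would stand apart from methyl with the six-membered ring in place.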